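This account rests on a few compounds, and the source may have more. Where it says the series, first, only, none or still open, it means among the compounds named here.

In an ADME assay on Vero cells (Chlorocebus sabaeus) for cytotoxicity, read by neutral red uptake, tested at 12.3 ug/mL (a higher number here means a weaker effect of the compound at the concentration tested, a lower number a stronger effect), compound 2 `O=C1CSC(c2cccc(O)c2)N1CCN1CCCCC1` gives 100%. Compound 1 `O=C1CSC(c2c(Cl)cccc2Cl)N1CCN1CCCCC1` gives 100% and compound 3 `O=C1CSC(c2ccc(O)cc2)N1CCN1CCCCC1` gives 100%, so compound 2 stands level with both at the digits shown, with nothing between them beyond the usual scatter. For the measured compounds named here, the one measured step within this set, no change at the digits printed from compound 2 to compound 3 (within the scatter), is the swap of 4-hydroxyphenyl in place of 3-hydroxyphenyl on a saturated ring carbon, and it moved nothing.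

Compound 4 `O=C1CSC(c2ccccc2Cl)N1CCN1CCCCC1` has not yet been tested. It differs from compound 2 by 2-chlorophenyl in place of 3-hydroxyphenyl on a saturated ring carbon. Going by the values given here, no measured step exchanges a hydroxyl-bearing ring for a chlorine-bearing one, so the only guide is that compound 1, whose aromatic ring carries chlorine rather than hydroxyl, also gave 100%, and that the single measured step showed no change. No step beyond the scatter is therefore expected in this assay. Compound 4 is expected to give 100%, with a likely range from 88% to 108%. The expected step is no change at the digits printed from compound 2 to compound 4 (within the scatter), that is, none beyond the scatter.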

Compound 4, a percentage reported as activity, at one concentration (the size of the read-out at that concentration, not a potency): 100%
Compound 4: the middle estimate sits on the measured number at the digits printed; the range from low to high includes it.
By their numbers in this assay, from the lowest: compounds 1, 2, 3 and 4 (each within the scatter of the next).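

In this assay, 2-chlorophenyl in place of a hydroxyphenyl on this saturated ring carbon gives no change at the digits printed from compound 2 to compound 4 (within the scatter) and no change at the digits printed from compound 3 to compound 4 (within the scatter), so among these compounds, losing the hydroxyl and its hydrogen-bond donor leaves the read-out unmoved. Hydrogen in place of one chloro on the aromatic ring gives no change at the digits printed from compound 1 to compound 4 (within the scatter), so the ring with one chlorine and the ring with two read alike. Nothing at hand offers a reason for this flat result.

Still open, on these data alone, is whether an aromatic ring bearing an amine or a carboxylic acid, or a longer chain in place of the ring, would read the same at this position. These readings also come from a single concentration and say nothing about how the compounds behave at higher ones.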